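The compounds below may be only part of what the source reports. "The series", "measured", "known", "first", "only" and "open" are said of these compounds alone.

Of the compounds shown here, three built on one shared core have been tested in an ADME assay on Huh-7 cells (Homo sapiens) for cytotoxicity; on this read-out lower numbers stand for higher toxicity in this test and higher numbers for lower toxicity in this test. Compound 1 `Cc1ccccc1-c1nn(-c2ccc(Cl)cc2)cc1CNCCN1CCN(C)CC1` gives 17000 nM in this assay. Compound 2 `Cc1ccccc1-c1nn(-c2ccc(C(F)(F)F)cc2)cc1CNCCN1CCN(C)CC1` gives 11000 nM in this assay. Compound 3 `Cc1ccccc1-c1nn(-c2cccc(C(F)(F)F)c2)cc1CNCCN1CCN(C)CC1` gives 18000 nM in this assay. The cores of compound 2 and compound 3 differ by 3-(trifluoromethyl)phenyl in place of 4-(trifluoromethyl)phenyl on an aromatic nitrogen. All three numbers lie within the scatter of one another: a 1.5-fold higher number from compound 2 to compound 1 (0.19 log units; within the scatter), a 1.1-fold higher number from compound 1 to compound 3 (0.02 log units; within the scatter) and a 1.6-fold higher number from compound 2 to compound 3 (0.21 log units; within the scatter).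

Compound 4 `Cc1ccccc1-c1nn(-c2cccc(Cl)c2)cc1CNCCN1CCN(C)CC1` has not yet been measured in this assay. It differs from compound 3 by chloro in place of trifluoromethyl on an aromatic carbon. The same kind of change separates compound 2 from compound 1, namely (chloro in place of trifluoromethyl on an aromatic carbon), where the place is para to a large group rather than meta to a large group; that earlier step was a 1.5-fold higher number from compound 2 to compound 1 (0.19 log units; within the scatter). Since that step stayed within the scatter, and since compound 3 gives 18000 nM in this assay, the step from compound 3 to compound 4 is expected to be a 1.2-fold higher number from compound 3 to compound 4 (0.09 log units; within the scatter). Compound 4 is therefore estimated at 22000 nM in this assay, with a likely range from 10000 nM to 45000 nM.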

Compound 4, half-maximal cytotoxic concentration: 16000 nM
Beside the measured number, compound 4's estimate is 1.4-fold (0.14 log units) above it, within the range that was stated.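

In this assay, chloro in place of trifluoromethyl gives a 1.1-fold lower number from compound 3 to compound 4 (0.05 log units; within the scatter), while the two steps that exchange the group on the aromatic nitrogen give a 1.5-fold higher number from compound 2 to compound 4 (0.16 log units; within the scatter) and a 1.1-fold lower number from compound 1 to compound 4 (0.03 log units; within the scatter). Set beside the earlier case, the same change reads alike on both cores, the two steps lying no further apart than the scatter allows: the same change on two cores in this assay, a 1.5-fold higher number (0.19 log units; within the scatter) from compound 2 to compound 1 and a 1.1-fold lower number (0.05 log units; within the scatter) from compound 3 to compound 4, 1.7-fold (0.24 log units) apart, within the scatter of two such steps. This shows that the change left the number within the scatter on both cores, but it does not show that the change has a size or direction of its own, or that it would behave the same way on a core not shown here.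

The compounds shown carry only chloro or trifluoromethyl on that ring, so the effect of a nitrile, a methoxy group or an amine there remains open. From the compounds shown here alone, the rest of the shared core stays the same throughout, so it is also open whether a carboxylic acid or a longer chain elsewhere would move the number beyond the scatter.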